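The source may hold more compounds than are shown below. What is called first, only, known or untested is meant among the compounds shown, and "the series" means these compounds.

- Compound 1 `Cc1ccncc1-c1cccc2c1cnn2-c1nccs1`: 69%
- Compound 2 `Cc1ccncc1-c1cccc2c1cnn2-c1cccnn1`: 89%
- Compound 3 `Cc1ccncc1-c1cccc2c1cnn2-c1ccccc1`: not yet measured

In an ADME assay on liver for metabolic stability, with Liver microsome (Homo sapiens) as the target, using microsomes, with a stated time of 10 min, tested at 0.5 uM (on this read-out higher numbers stand for a more stable compound and lower numbers for a less stable compound), compound 2 holds the higher of the two numbers, at 89%, while compound 1 gives 69%. Compound 3 keeps the shared core but carries phenyl in place of pyridazin-3-yl on an aromatic nitrogen. Among the measured compounds shown here, only one measured step bears on this change, and it swaps the ring at that same place: a number 20 percentage points higher from compound 1 to compound 2 (beyond the scatter). For the measured compounds named here, it is modest in size, and it is the only guide, since no measured compound carries phenyl there. With compound 2 already at 89%, little room remains upward on this read-out, so a fall of similar size seems the likelier outcome. The expected change is a number 21 percentage points lower from compound 2 to compound 3 (beyond the scatter). For compound 3, the estimated value is 68%, with an expected range from 45% to 85%.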

Compound 3, percent of the compound remaining: 78%
For compound 3 the middle estimate is 10 percentage points below the measured one; measured number inside the range.
By their numbers in this assay, from the lowest: compounds 1 and 3 (each within the scatter of the next); then compound 2.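

In this assay, exchanging one six-membered aromatic ring for another at this place on the aromatic nitrogen still moves the number: the change to phenyl gives a number 11 percentage points lower from compound 2 to compound 3 (beyond the scatter), so the two ring nitrogens of pyridazin-3-yl go with a real difference among rings of equal size. Phenyl and 1,3-thiazol-2-yl, by contrast, cannot be told apart, with a number 9 percentage points higher from compound 1 to compound 3 (within the scatter), so among these three groups only pyridazin-3-yl stands clear of both others. No measurement here gives a reason for this difference.

Still open, as far as these compounds go, is where a ring with a single nitrogen, such as pyridin-2-yl, would fall relative to phenyl and pyridazin-3-yl. From the compounds shown here alone, it is equally open whether this place needs an aromatic ring at all, as a morpholine or a short alkyl chain would test.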